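Benzyl triazole ethers: bromine for fluorine at the assay limit

A few compounds are considered here, and "the series" means these few. Any claim that something is new, unique, unknown or untested is made for them only; others in the source may bear on it.

Compound 3 `O=c1ccoc2cc(OCc3cn(Cc4cccc(F)c4)nn3)ccc12` carries a 3-fluorobenzyl group on the shared core. In a functional assay on QGY7701 cells (Homo sapiens) for cytotoxicity, read by MTT assay, with a stated time of 48 h (a lower number here means a stronger inhibitor, a higher number a weaker inhibitor), compound 3 gives only a limit, > 100000 nM. Compound 2 `O=c1ccoc2cc(OCc3cn(Cc4ccc([N+](=O)[O-])cc4)nn3)ccc12` likewise reaches only a limit, > 100000 nM. For the measured compounds named here, compound 1 `Cc1ccc(Cn2cc(COc3ccc4c(=O)ccoc4c3)nn2)cc1` gives 68500 nM, the single number in the set; the step of an at least 1.4-fold higher number from compound 1 to compound 3 (0.16 log units; that floor lies within the scatter) has its floor within the scatter, and the step that the two limits leave unreadable from compound 2 to compound 3 cannot be read, since the limit of > 100000 nM in this assay, at which 2 of the 3 values shown sit, is where most of the set sits. Compound 4 `O=c1ccoc2cc(OCc3cn(Cc4ccccc4Br)nn3)ccc12` differs from compound 3 by 2-bromophenyl in place of 3-fluorophenyl on a saturated chain carbon bound to an aromatic nitrogen. Going by the values given here, no measured step involves a bromine, so the change can be judged only against a series that sits at the limit. Compound 4 is expected to give 100000 nM, with a range from 40000 nM to 300000 nM, most likely reported again as a limit. The estimated step of a number no higher from compound 3 to compound 4 (the limit leaves the size open) is expected to stay within the scatter.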

Compound 4, half-maximal inhibitory concentration: > 100000 nM
Compound 4: a limit, no number; the forecaster's own chance of this, stated with the estimate: 70%; the middle value lies on the limit itself.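

In this assay, for the compounds shown here, compound 4 gives > 100000 nM, also a limit, so a bromine-bearing group, 2-bromophenyl, now joins the groups at this limit on a saturated chain carbon bound to an aromatic nitrogen: the limit of > 100000 nM in this assay, at which 3 of the 4 values shown sit. Against the only numbered value, the change gives an at least 1.4-fold higher number from compound 1 to compound 4 (0.16 log units; that floor lies within the scatter), so no separation from 4-methylphenyl can be claimed. The steps among the compounds at the limit cannot be read.

On these data alone, whether any group here gives a number clearly under the limit stays open. A benzyl carrying an amine or a carboxylic acid, or a longer chain in place of benzyl, would test this.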